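Swapping a Side Chain for Isopropyl: Expected Effect

A few compounds are considered here, and "the series" means these few. Any claim that something is new, unique, unknown or untested is made for them only; others in the source may bear on it.

Of the compounds shown here, two sharing one core have been measured in a functional assay on the whole organism (Tail, strain ICR) with Mus musculus as the target, in the tail flick test, with a stated time of 90 min, at a dose of 25 umol/kg by the oral route; on this read-out lower numbers stand for a weaker effect and higher numbers for a stronger effect at the one dose given. Compound 1 `NC(=O)CC[C@H](NC(=O)CN(c1ncnc2c1ncn2C1CCCCO1)C1CC1)C(=O)OCc1ccccc1` carries a carbamoylmethyl group on its side chain, and in this assay compound 1 gives 37.8%. Compound 2 `O=C(CN(c1ncnc2c1ncn2C1CCCCO1)C1CC1)N[C@@H](CC(=O)OCc1ccccc1)C(=O)OCc1ccccc1` carries a benzyloxycarbonyl group in that position instead, and in this assay compound 2 gives 25.1%. Going by the values given here, the one step seen so far, a number 12.7 percentage points lower from compound 1 to compound 2 (beyond the scatter), shows that replacing the carbamoylmethyl group weakened the effect, and compound 2 stands as the lower of the two numbers measured.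

Compound 3 `CC(C)[C@H](NC(=O)CN(c1ncnc2c1ncn2C1CCCCO1)C1CC1)C(=O)OCc1ccccc1` differs from compound 2 in a single place: isopropyl in place of (benzyloxycarbonyl)methyl on a saturated chain carbon bound to an amide-type nitrogen and a carbonyl carbon. Among the compounds with values here, no measured pair shows this particular exchange. Within the data shown here, the only step available, a number 12.7 percentage points lower from compound 1 to compound 2 (beyond the scatter), concerns a different group entering at a neighbouring position and therefore bears on compound 3 only loosely: it shows that changing this part of the molecule can move the read-out by a modest amount. With so little to go on, the expected step of a number 6.9 percentage points higher from compound 2 to compound 3 (within the scatter) is small and within the scatter. Compound 3 is estimated to give 32%, with a range from 12% to 55%.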

Compound 3, a percentage reported as activity, at one dose (the size of the read-out at that dose, not a potency): 30.1%
Beside the measured number, compound 3's estimate is 1.9 percentage points above it, within the range that was stated.
By their numbers in this assay, from the lowest: compounds 2, 3 and 1 (each within the scatter of the next, the first and the last beyond it).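

In this assay the exchange on the saturated chain carbon bound to an amide-type nitrogen and a carbonyl carbon gives a number 5 percentage points higher from compound 2 to compound 3 (within the scatter) and so shows that (benzyloxycarbonyl)methyl, with 11 heavy atoms and an aromatic ring, can give way to isopropyl, with 3 heavy atoms and no ring, without a difference that stands out from the scatter. The comparison with the other side chain gives a number 7.7 percentage points lower from compound 1 to compound 3 (within the scatter) and so places isopropyl within the scatter of 2-carbamoylethyl as well, even though compound 1 and compound 2 lie beyond the scatter of each other; compound 3 therefore sits between two values that can be separated but cannot itself be separated from either one. No supporting measurement is available to explain these numbers.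

As far as these compounds go, how an amine, a carboxylic acid or a longer hydrocarbon chain on this carbon would compare with isopropyl remains open. Because the read-out comes from one dose at one stated time, it also leaves open how these compounds would compare at other doses or other times.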